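The compounds below may be only part of what the source reports. "The series", "measured", "known", "first", "only" and "open" are said of these compounds alone.

Measured compounds:
- compound 1, `COC(=O)CNC(=O)NCc1ccc(C(=O)N2CCCCc3ccccc32)cc1C`: 37 nM
- compound 2, `CCOC(=O)CNC(=O)NCc1ccc(C(=O)N2CCCCc3ccccc32)cc1C`: 140 nM
- compound 3, `Cc1cc(C(=O)N2CCCCc3ccccc32)ccc1CNC(=O)N1CCC[C@H]1C(=O)OC(C)(C)C`: 390 nM

In a functional assay on HEK293 cells for agonist activity at Vasopressin V2 receptor (Homo sapiens), read by a luciferase reporter and cAMP accumulation (a higher number here means that more compound is needed for the effect, a lower number that less compound is needed), compound 3 stands highest of the three numbers. Its nearest neighbour is compound 2, at a 2.8-fold higher number from compound 2 to compound 3 (0.44 log units; beyond the scatter), and its furthest is compound 1, at an 11-fold higher number from compound 1 to compound 3 (1.02 log units; beyond the scatter). Both steps exchange a glycine-ester urea for the proline-ester urea and run in the same direction. Within the data shown here, the only other step, a 3.8-fold higher number from compound 1 to compound 2 (0.58 log units; beyond the scatter), shows that enlarging the ester alkyl also raises the number.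

Compound 4, `CO[C@@H]1C[C@@H](C(=O)N(C)C)N(C(=O)NCc2ccc(C(=O)N3CCCCc4ccccc43)cc2C)C1`, differs from compound 3 by 2-(dimethylcarbamoyl)-4-methoxypyrrolidin-1-yl in place of 2-(tert-butoxycarbonyl)pyrrolidin-1-yl on a carbonyl carbon. Among the measured compounds shown here, no measured pair exchanges an ester for a dimethylamide or adds a methoxy group to the pyrrolidine, so no step bears directly on this change. The three steps together show that this region tolerates variation only with modest to large shifts, all upward. Without a direct precedent, compound 4 is expected to stay near compound 3, with the step of a 1.2-fold lower number from compound 3 to compound 4 (0.09 log units; within the scatter) judged within the scatter, and the estimate for compound 4 in this assay is 320 nM, ranging from 80 nM to 1300 nM.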

Compound 4, half-maximal effective concentration: 4.7 nM
Estimate against measurement, compound 4: 68-fold (1.83 log units) above; the measured number lies below the stated range.
By their numbers in this assay, from the lowest: compound 4; then compound 1; then compound 2; then compound 3.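

In this assay every earlier change on this carbonyl carbon raised the number, whereas 2-(dimethylcarbamoyl)-4-methoxypyrrolidin-1-yl gives an 83-fold lower number from compound 3 to compound 4 (1.92 log units; beyond the scatter) and shows that a pyrrolidine on this carbon is compatible with a low number. The same group also gives a 30-fold lower number from compound 2 to compound 4 (1.47 log units; beyond the scatter) and a 7.9-fold lower number from compound 1 to compound 4 (0.90 log units; beyond the scatter) and so reverses the order seen so far, with the pyrrolidine now lower than both glycine-ester ureas and compound 4 the lowest of the four numbers. Nothing in the available data explains this drop.

Compound 4 differs from compound 3 in both the dimethylamide and the methoxy group, so the compounds shown cannot divide the step between them. Also open, going by these compounds, is how a carboxylic acid at the amide's place, or a hydroxy group in place of the methoxy, would read here.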